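Halogen swap on the aryl ring: bromo to chloro

This account rests on a few compounds, and the source may have more. Where it says the series, first, only, none or still open, it means among the compounds named here.

compound 1, `Cc1ccc(C2=NN(c3nc(-c4ccc(C(F)(F)F)cc4)cs3)C(c3cccs3)C2)cc1`: 2110 nM
compound 2, `FC(F)(F)c1ccc(-c2csc(N3N=C(c4ccc(Br)cc4)CC3c3cccs3)n2)cc1`: 27400 nM

Compound 2 gives the highest number of the two in a functional assay on WM 266-4 cells (Homo sapiens) for antiproliferative activity, read by MTT assay, with a stated time of 48 h; a lower number here means a stronger inhibitor, a higher number a weaker inhibitor; its nearest neighbour is compound 1, and the step of a 13-fold higher number from compound 1 to compound 2 (1.11 log units; beyond the scatter) separates them. Compound 3 `FC(F)(F)c1ccc(-c2csc(N3N=C(c4ccc(Cl)cc4)CC3c3cccs3)n2)cc1` differs from compound 2 by chloro in place of bromo on an aromatic carbon. Among the measured compounds shown here, no measured step exchanges one halogen for another; the only step available, a 13-fold higher number from compound 1 to compound 2 (1.11 log units; beyond the scatter), concerns methyl giving way to bromo and does not bear directly on this change. For compound 3 a step within the scatter is therefore expected, a 1.4-fold lower number from compound 2 to compound 3 (0.14 log units; within the scatter). Compound 3 is expected to give 20000 nM, between 7000 nM and 60000 nM.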

Compound 3, half-maximal inhibitory concentration: 120 nM
For compound 3 the middle estimate is 170-fold (2.22 log units) above the measured one; the measured number lies below the stated range.
By their numbers in this assay, from the lowest: compound 3; then compound 1; then compound 2.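

In this assay, the exchange of one halogen for another is far from a quiet change at this place on the aryl ring: chloro in place of bromo produces a very large shift (a 230-fold lower number from compound 2 to compound 3 (2.36 log units; beyond the scatter)). Chloro also surpasses methyl at the same place (an 18-fold lower number from compound 1 to compound 3 (1.25 log units; beyond the scatter)), so the poor result for bromo cannot be read as a penalty on halogens in general. Nothing measured here explains why the two halogens part so sharply. The three compounds leave open how fluoro, a methoxy group or an amine would fare at this place, and whether the gap between chloro and bromo persists when the thiophene or trifluoromethyl-bearing parts are changed.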